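The compounds below may be only part of what the source reports. "The series", "measured", "known", "first", "only" and "open" are said of these compounds alone.

Series of arylacetic acid derivatives sharing one core, tested in a functional assay on the whole organism (strain Wistar) for inhibition, with Rattus norvegicus as the target, read by paw edema, with stated times of 60 min and 24 h, at a dose of 100 mg/kg by the oral route; a lower number here means less inhibition, a higher number more inhibition at the dose given (going by the name of the read-out). Compound 1 `COc1cc2c(cc1OC)C(CC(=O)O)CC2` gives 26.7%. Compound 2 `CCN(CC)C(=O)CC1CCc2cc(OC)c(OC)cc21` gives 16.7%, and compound 3 `COc1cc2c(cc1OC)C(CC(=O)NC(C)(C)C)CC2` gives 40%. Compound 2 stands lowest of the three numbers; the step of a number 10 percentage points lower from compound 1 to compound 2 (within the scatter) lies within the scatter, whereas a number 23.3 percentage points higher from compound 2 to compound 3 (beyond the scatter) and a number 13.3 percentage points higher from compound 1 to compound 3 (beyond the scatter) both lie beyond it.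

Compound 4 `COc1cc2c(cc1OC)C(CC(=O)NC1CCCCC1)CC2` is not yet measured. It differs from compound 2 by cyclohexylamino in place of diethylamino on a carbonyl carbon. The step that bears most directly on this change is a number 23.3 percentage points higher from compound 2 to compound 3 (beyond the scatter), where the diethylamino group of compound 2 was likewise replaced by a single-substituent amino group carrying one hydrogen-bond donor. Cyclohexylamino, like tert-butylamino, enters with one hydrogen-bond donor, so a rise of comparable size is expected in this assay, though the series holds no second case to confirm it. Compound 4 is therefore expected to give 38%, within a range of 22% to 55%, meaning an estimated step of a number 21.3 percentage points higher from compound 2 to compound 4 (beyond the scatter).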

Compound 4, a percentage reported as inhibition, in the whole organism at one dose (the size of the read-out at that dose, not a potency): 53.3%
Estimate against measurement, compound 4: 15.3 percentage points below; measured number inside the range.
By their numbers in this assay, from the lowest: compounds 2 and 1 (each within the scatter of the next); then compound 3; then compound 4.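

In this assay, the amide hydrogen is present in both compound 3 and compound 4, yet cyclohexyl in place of tert-butyl on the amide-type nitrogen still gives a number 13.3 percentage points higher from compound 3 to compound 4 (beyond the scatter), so the rise at this position does not follow the hydrogen-bond donor count alone. The same change also gives a number 36.6 percentage points higher from compound 2 to compound 4 (beyond the scatter), the largest step listed for the series, and replacing hydroxy on the carbonyl carbon gives a number 26.6 percentage points higher from compound 1 to compound 4 (beyond the scatter). Compound 4 is therefore the highest of the four, beyond the scatter of each of the others.

On these data alone, it remains open whether the ring itself or the larger carbon count matters, which cyclopentylamino, unbranched hexylamino or anilino on the same carbonyl carbon could help separate. No measured information on hand explains the differences at this position.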